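A Phenoxy Swap on Compound 2

A few compounds are considered here, and "the series" means these few. Any claim that something is new, unique, unknown or untested is made for them only; others in the source may bear on it.

In an ADME assay on BJ cells (Homo sapiens) for cytotoxicity, read by luminescence, with a stated time of 72 h (a lower number here means that less compound is needed, a higher number that more compound is needed for the effect), compound 1 `CCOC(=O)c1c(-c2cccc(Oc3ccccc3)c2)[nH]c2cc(OC)c(F)cc2c1=O` gives > 21500 nM as a limit and not a number. Compound 2 `CCOC(=O)c1c(-c2cccc(-c3c(C)cccc3C)c2)[nH]c2cc(OC)c(F)cc2c1=O` gives > 21500 nM and this too is a limit. Within the data shown here, the only measured change is a step that the two limits leave unreadable from compound 1 to compound 2 and it offers no size to carry forward. Compound 3 `CCOC(=O)c1c(-c2cccc(Oc3c(C)cccc3C)c2)[nH]c2cc(OC)c(F)cc2c1=O` differs from compound 2 by 2,6-dimethylphenoxy in place of 2,6-dimethylphenyl on an aromatic carbon and so has 2,6-dimethylphenoxy in place of 2,6-dimethylphenyl. Among the measured compounds shown here, with the limit of > 21500 nM in this assay, at which 2 of the 2 values shown sit, as the only guide, no step beyond the scatter is expected in this assay and another limit is likely. The expected change is a step that the limit leaves unreadable from compound 2 to compound 3 as an estimate. Compound 3 is expected at about 25000 nM with an estimated range from 12000 nM to 50000 nM as its span.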

Compound 3, half-maximal effective concentration: > 21500 nM
Compound 3 was reported as a limit; the forecaster's own chance of this, stated with the estimate: 85%; the middle value lies beyond the limit too.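

Compound 1, compound 2 and compound 3 all give limits and not numbers, so no step among them can be read: the limit of > 21500 nM in this assay, at which 3 of the 3 values shown sit.

On these data alone, how these three compounds compare in this assay stays open, and so does whether swapping these groups changes the result at all.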